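The source may hold more compounds than are shown below. What is called first, only, known or untested is meant among the compounds shown, and "the series" means these compounds.

Among the measured compounds shown here, compound 2 `O=C(COc1cccc2ccccc12)N/N=C/c1cccc(O)c1` gives 3.73 in a physicochemical assay for lipophilicity, measured as octanol-water partition (on this read-out lower numbers stand for lower lipophilicity and higher numbers for higher lipophilicity), the lowest of the two numbers measured so far. Compound 1 `O=C(COc1cccc2ccccc12)N/N=C/c1ccccc1[N+](=O)[O-]` gives 3.97 in this assay, a number that lies close enough to that of compound 2 for the two to count as indistinguishable within the usual scatter. Compound 3 `O=C(COc1cccc2ccccc12)N/N=C/c1ccccc1Cl` has not yet been measured in this assay. It differs from compound 2 in a single place: 2-chlorophenyl in place of 3-hydroxyphenyl on a carbon with a double bond to nitrogen. For the measured compounds named here, no step between two measured compounds describes this exchange, so the expectation rests on the structures alone. A change that removes 1 hydrogen-bond donor and 1 hydrogen-bond acceptor and brings in a chlorine is expected to move the number in this assay upward, by a step well beyond the scatter, a number 0.87 log units higher from compound 2 to compound 3 (beyond the scatter). On that basis compound 3 is estimated at 4.6, with a plausible range from 4.2 to 5.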

Compound 3, partition coefficient: 4.54
Beside the measured number, compound 3's estimate is 0.06 log units above it; measured number inside the range.
By their numbers in this assay, from the lowest: compounds 2 and 1 (each within the scatter of the next); then compound 3.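

In this assay, among the compounds shown here, compounds 1 and 2 lie within the scatter of each other, so the earlier compounds did not show that the group on this carbon can shift the number measurably. Now 2-chlorophenyl in place of 3-hydroxyphenyl gives a number 0.81 log units higher from compound 2 to compound 3 (beyond the scatter) and chloro in place of nitro on an aromatic carbon gives a number 0.57 log units higher from compound 1 to compound 3 (beyond the scatter), which sets compound 3 apart from both. Nothing measured here accounts for either step.

The compounds shown leave open whether 3-chlorophenyl would stand with compound 3 or closer to compound 2 in this assay, since the exchange from compound 2 changes both the group and the name of its ring position. Where an amine or a carboxylic acid on that ring would fall also remains open.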